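Lipophilicity notes: oxadiazole-linked aryl series, compound 3

A few compounds are considered here, and "the series" means these few. Any claim that something is new, unique, unknown or untested is made for them only; others in the source may bear on it.

Measured so far:
compound 1 `CC(C)(C)n1ncc(OCc2nnc(-c3ccccc3Cl)o2)c(Cl)c1=O` — 3.19
compound 2 `CC(C)(C)n1ncc(OCc2nnc(-c3ccccc3F)o2)c(Cl)c1=O` — 2.89

In a physicochemical assay for lipophilicity (on this read-out lower numbers stand for lower lipophilicity and higher numbers for higher lipophilicity), compound 1 stands highest of the two numbers; its nearest neighbour is compound 2, and the step of a number 0.30 log units lower from compound 1 to compound 2 (within the scatter) lies within the scatter. Compound 3 `CC(C)(C)n1ncc(OCc2nnc(-c3cc(F)c(Cl)cc3Cl)o2)c(Cl)c1=O` differs from compound 1 by 2,4-dichloro-5-fluorophenyl in place of 2-chlorophenyl on an aromatic carbon. Within the data shown here, no measured step covers this change directly; the single step from compound 1 to compound 2 swaps one halogen for another, whereas here two halogens are added to the aromatic carbon ring. A rise beyond the scatter is therefore expected for compound 3, as the step of a number 0.76 log units higher from compound 1 to compound 3 (beyond the scatter). Compound 3 is estimated at 3.95, from 3.5 to 4.4.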

Compound 3, partition coefficient: 3.36
Compound 3: the middle estimate sits 0.59 log units above what was measured, and the stated range ends above it.
By their numbers in this assay, from the lowest: compounds 2, 1 and 3 (each within the scatter of the next, the first and the last beyond it).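

In this assay, 2,4-dichloro-5-fluorophenyl in place of 2-chlorophenyl on this aromatic carbon gives a number 0.17 log units higher from compound 1 to compound 3 (within the scatter), so the extra halogens do not separate these two compounds on this read-out. Among these compounds, in place of 2-fluorophenyl, the same group gives a number 0.47 log units higher from compound 2 to compound 3 (beyond the scatter), the only step beyond the scatter among the three compounds. No available evidence bears on these steps.

Going by these compounds, the contribution of each added halogen remains open, since they change together here. Also open, on these data alone, is how a non-halogen group on the phenyl ring, such as an amine or a carboxylic acid, would compare.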